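A Nitro Group Added to the Bare Phenyl of Compound 3

The source may report more compounds than this note shows. Statements on the series, on what has been measured and on what is new or still open speak of the compounds shown alone.

Compound 3 `O=C(COc1ccc(C(=O)/C=C/c2ccccc2)cc1)N[C@H]1CCOC1=O` carries an unsubstituted phenyl at the end of the enone chain. In a functional assay on MCF7 cells (Homo sapiens) for antiproliferative activity, read by MTT assay, with a stated time of 72 h (on this read-out lower numbers stand for stronger inhibition and higher numbers for weaker inhibition), compound 3 gives > 64000 nM, which is a limit of the assay and not a measured number. Compound 1 `O=C(COc1ccc(C(=O)/C=C/c2ccccc2Br)cc1)N[C@H]1CCOC1=O` bears a bromo on that ring and gives 15300 nM in this assay. Compound 2 `CC(C)c1ccc(/C=C/C(=O)c2ccc(OCC(=O)N[C@H]3CCOC3=O)cc2)cc1` bears an isopropyl instead and gives 23400 nM. Against compound 3 these two read as an at least 4.1-fold higher number from compound 1 to compound 3 (0.62 log units; beyond the scatter) and an at least 2.7-fold higher number from compound 2 to compound 3 (0.43 log units; beyond the scatter), so removing either group pushes the value up to the limit (the limit of > 64000 nM in this assay, at which 1 of the 3 values shown sits). Compound 4 `O=C(COc1ccc(C(=O)/C=C/c2cccc([N+](=O)[O-])c2)cc1)N[C@H]1CCOC1=O` differs from compound 3 by nitro in place of hydrogen on an aromatic carbon. Both measured steps concern a substituent leaving the ring, and both point the same way: a substituted phenyl gives a lower number than the bare one. Neither step involves a nitro, so the size of the effect for compound 4 is uncertain, but the direction is taken from them. A downward step of an at least 2.1-fold lower number from compound 3 to compound 4 (0.32 log units; beyond the scatter) is therefore expected. Compound 4 is estimated at 30000 nM, with a range from 10000 nM to 80000 nM, and a real chance remains that only a limit is reported.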

Compound 4, half-maximal inhibitory concentration: > 64000 nM
Compound 4: a limit, no number; the forecaster's own chance of this, stated with the estimate: 35%; at least 2.1-fold (0.32 log units) between middle value and limit.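

The 3-nitrophenyl ring does not join the two substituted rings that read below the limit in this assay, with an at least 4.1-fold higher number from compound 1 to compound 4 (0.62 log units; beyond the scatter) and an at least 2.7-fold higher number from compound 2 to compound 4 (0.43 log units; beyond the scatter). A substituent on this ring is therefore not enough on its own to give a measured number: 2-bromophenyl and 4-isopropylphenyl do so among the compounds shown, while compound 4 goes against that pattern. Compound 4 gives only a limit and compound 3 does as well, so the step between them cannot be read, and the nitro can be neither credited with a gain nor charged with a loss: the limit of > 64000 nM in this assay, at which 2 of the 4 values shown sit.

The compounds shown leave open whether the outcome belongs to the nitro itself or to its place on the ring, as none of them carries one group at two different places. They also leave open how an amine or a methoxy group on this ring would read in this assay, and whether either would give a number or a limit.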